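The source may hold more compounds than are shown below. What is called first, only, known or untested is meant among the compounds shown, and "the series" means these compounds.

Measured compounds in a functional assay on SF-268 cells (Homo sapiens) for cytotoxicity, read by sulforhodamine B assay, with a stated time of 48 h; on this read-out lower numbers stand for stronger inhibition of growth and higher numbers for weaker inhibition of growth:
Compound 1, `ClCc1ccccc1Cn1cnc2c(Cl)ncnc21`, gives 3230 nM.
Compound 2, `ClCc1cccc(Cn2cnc3ncnc(Cl)c32)c1`, gives 1650 nM.
Compound 3, `ClCc1cccc(Cn2cnc3c(Cl)ncnc32)c1`, gives 3540 nM.

Among these three, compound 2 has the lowest number in this assay. Its gap to compound 1 lies within the usual scatter of repeated measurements of this kind, so no order can be read between compound 2 and compound 1. Its gap to compound 3 lies beyond that scatter, so compound 2 inhibits growth more strongly than compound 3 in this assay.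

Compound 4, `ClCc1cccc(Cn2cnc3nc(Cl)nc(Cl)c32)c1`, has not yet been measured in this assay. It differs from compound 2 by chloro in place of hydrogen on an aromatic carbon. Within the data shown here, no pair among the measured compounds carries this same change, so there is no measured step to lean on; the three measured values in this assay all sit in a fairly narrow band, and the change adds only a chloro group to the shared core. The step in this assay is therefore expected to be small, with no clear direction beyond the scatter, and the expected step is a 1.1-fold lower number from compound 2 to compound 4 (0.04 log units; within the scatter). Compound 4 is estimated to give 1500 nM in this assay, within a range from 500 nM to 5000 nM.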

Compound 4, concentration for 50% growth inhibition: 2130 nM
Compound 4: middle estimate off by 1.4-fold (0.15 log units), on the low side; the range from low to high includes it.
By their numbers in this assay, from the lowest: compounds 2, 4, 1 and 3 (each within the scatter of the next, the first and the last beyond it).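

In this assay the series now has its first measured step between two compounds that differ in one place: chloro in place of hydrogen, on an aromatic carbon between two ring nitrogen atoms, gives a 1.3-fold higher number from compound 2 to compound 4 (0.11 log units; within the scatter). Among these compounds, no order can be read between this pair, so this carbon of the shared core carries a chloro group without a change in growth inhibition that this assay can resolve, a point the earlier compounds could not address. Nothing available bears on what lies behind this result.

The compounds shown leave open whether a group other than chloro on this same carbon, such as an amine, a methoxy group or a longer chain, would move the number beyond the scatter in either direction. They also leave open whether the same chloro step would hold on the cores of compound 1 and compound 3, as this change is seen in a single pair only.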